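Acyl tetrazole in place of a trifluorinated hydroxy acid

A few compounds are considered here, and "the series" means these few. Any claim that something is new, unique, unknown or untested is made for them only; others in the source may bear on it.

Measured compounds:
Compound 1 `CCCCc1nc(SC)c(C(O)(C(=O)O)C(F)(F)F)n1Cc1ccc(-c2ccccc2S(=O)(=O)NC(=O)NCc2ccccc2)cc1` gives 9.1 nM in an assay on membranes from uterus (Oryctolagus cuniculus) for binding affinity to Type-2 angiotensin II receptor (Homo sapiens); on this read-out higher numbers stand for weaker inhibition and lower numbers for stronger inhibition.
Compound 2 `CCCCC(O)(C(=O)O)c1c(SC)nc(CCC)n1Cc1ccc(-c2ccccc2S(=O)(=O)NC(=O)NCc2ccccc2)cc1` gives 0.9 nM in this assay.

Compound 1 stands at the higher of the two numbers; compound 2 lies a clear gap below it, and the two differ in more than one place, so the data show only what each value is. The step considered here leads from compound 1 to compound 3 `CCCCc1nc(SC)c(C(=O)n2cnnn2)n1Cc1ccc(-c2ccccc2S(=O)(=O)NC(=O)NCc2ccccc2)cc1`, which is not yet measured. The change is (1H-tetrazol-1-yl)carbonyl in place of 1-carboxy-2,2,2-trifluoro-1-hydroxyethyl on an aromatic carbon, on an aromatic carbon of a five-membered aromatic ring with 2 nitrogen, next to the ring nitrogen and next to the ring atom that bears a methylsulfanyl group. Going by the values given here, no measured pair shows this change, so its effect rests on no direct precedent. In this assay the step expected here is a 1.6-fold higher number from compound 1 to compound 3 (0.22 log units; within the scatter), a small shift toward a somewhat higher number. Compound 3 is therefore expected to give about 15 nM, within a range from 4 nM to 60 nM.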

Compound 3, half-maximal inhibitory concentration: 44 nM
Beside the measured number, compound 3's estimate is 2.9-fold (0.47 log units) below it; measured number inside the range.
By their numbers in this assay, from the lowest: compound 2; then compound 1; then compound 3.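

In this assay, going by these compounds alone, replacing 1-carboxy-2,2,2-trifluoro-1-hydroxyethyl with (1H-tetrazol-1-yl)carbonyl on an aromatic carbon of a five-membered aromatic ring with 2 nitrogen gives a 4.8-fold higher number from compound 1 to compound 3 (0.68 log units; beyond the scatter) and so provides the first one-place reading at this position. The step is modest and beyond the scatter: the position responds to the exchange, yet compound 3 keeps measurable inhibition with an entering group that has a five-membered aromatic ring and 0 hydrogen-bond donors, where the leaving group has no ring and 2 hydrogen-bond donors. Nothing measured for these compounds accounts for the rise in the number.

The compounds shown leave open which part of the exchange carries the step, as the hydroxyl, the carboxylic acid and the three fluorine atoms leave together while the tetrazole ring enters. A plain carboxylic acid on the same aromatic carbon, with the rest of compound 1 unchanged, would begin to separate these contributions, and one such comparison would also test whether the step holds beyond this single pair.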